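A few compounds are considered here, and "the series" means these few. Any claim that something is new, unique, unknown or untested is made for them only; others in the source may bear on it.

In an ADME assay on HepG2 cells (Homo sapiens) for inhibition, read by luminescence and CellTiter-Glo, with stated times of 24 h and 48 h (a higher number here means a weaker inhibitor, a lower number a stronger inhibitor), compound 1 (`Cc1ccc(C(=O)N(CC(=O)NCc2ccccc2)Cc2ccc(C(=O)NO)cc2)c(C)c1`) gives 3710 nM as the lowest of the two numbers in hand. Compound 2 (`CNC(=O)CN(Cc1ccc(C(=O)NO)cc1)C(=O)c1ccc(C(C)C)cc1`) gives 9160 nM and lies higher, beyond the scatter. Compound 3 (`CC(C)c1ccc(C(=O)N(Cc2ccc(C(=O)NO)cc2)C(C)(C)C(=O)NC2CCCCC2)cc1`) reads > 50000 nM which is a limit of the assay and not a number.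

Compound 4 (`Cc1ccccc1C(=O)N(CC(=O)NCc1ccccc1)Cc1ccc(C(=O)NO)cc1`) departs from compound 1 at one place (hydrogen in place of methyl on an aromatic carbon): hydrogen in place of methyl on an aromatic carbon, para to a large group, so 2,4-dimethylphenyl becomes 2-methylphenyl. Among the measured compounds shown here, no measured pair shows this change, so the estimated 1.2-fold higher number from compound 1 to compound 4 (0.08 log units; within the scatter) in this assay is small, has no firm direction and is not expected to go beyond the scatter. Compound 4 is expected at 4500 nM with an estimated range from 1800 nM to 11000 nM in this series.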

Compound 4, half-maximal inhibitory concentration: 9620 nM
Compound 4: middle estimate off by 2.1-fold (0.33 log units), on the low side; the range from low to high includes it.
By their numbers in this assay, from the lowest: compound 1; then compounds 2 and 4 (each within the scatter of the next). At a limit, above all of these: compound 3.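

In this assay, among the compounds shown here, the change from 2,4-dimethylphenyl to 2-methylphenyl gives a 2.6-fold higher number from compound 1 to compound 4 (0.41 log units; beyond the scatter) and is the first reading of this position, so a single methyl para to a large group counts. The earlier compounds shown here differ from one another in more than one place and could not isolate this position. Nothing at hand gives a cause for this step. Still open, as far as these compounds go, is whether an ethyl or methoxy group at this position would lower the number further, and whether the step holds with other amide side chains.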